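Bromo to Chloro in a Cyclic Guanidine Urea Series

A few compounds are considered here, and "the series" means these few. Any claim that something is new, unique, unknown or untested is made for them only; others in the source may bear on it.

Measured compounds:
- compound 1, `CC(C)c1cccc(C(C)C)c1NC(=O)/N=C1\CCCN1C`: "not determined" (no result reported)
- compound 2, `CN1CCC/C1=N\C(=O)Nc1cccc(C(F)(F)F)c1`: > 25 mg/kg
- compound 3, `CN1CCC/C1=N\C(=O)Nc1cccc(Br)c1`: 25 mg/kg

The three compounds share one core and differ in the substituent on the aryl ring. In a functional assay on the whole organism with Rattus norvegicus as the target, with a stated time of 5 days (a higher number here means that more compound is needed for the effect, a lower number that less compound is needed), compound 1 has no reported result, recorded as "not determined" (no result reported). In this assay compound 2 gives only a limit, > 25 mg/kg, and not a number. In this assay compound 3 gives 25 mg/kg. Within the data shown here, compound 3 thus holds the only actual number in the set; one further entry is a limit and one has no result at all. Among the measured compounds shown here, the single measured step, a number no higher from compound 2 to compound 3 (the limit leaves the size open), is left open in size by the limit of > 25 mg/kg in this assay, at which 1 of the 3 values shown sits, so it gives no readable magnitude to lean on.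

The unmeasured compound 4, `CN1CCC/C1=N\C(=O)Nc1cccc(Cl)c1`, differs from compound 3 by chloro in place of bromo on an aromatic carbon. For the measured compounds named here, no measured step touches the same change, and the one step that exists has no readable size, so there is no basis for expecting a shift beyond the scatter. The step from compound 3 to compound 4 is therefore expected to be small, no change at the digits printed from compound 3 to compound 4 (within the scatter). For compound 4 in this assay the estimate is 25 mg/kg, with a range from 12 mg/kg to 50 mg/kg.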

Compound 4, minimum effective dose: 15 mg/kg
Beside the measured number, compound 4's estimate is 1.7-fold (0.22 log units) above it; low and high end bracket the measured number.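

In this assay, the aromatic carbon meta to a large group now has its first step between two actual numbers: a 1.7-fold lower number from compound 3 to compound 4 (0.22 log units; within the scatter). Chloro and bromo therefore cannot be told apart at this position in this series, a reading that the earlier compounds, with only one number among them, could not give. Against trifluoromethyl, the result adds an at least 1.6-fold lower number from compound 2 to compound 4 (0.22 log units; that floor lies within the scatter), but this step starts from a limit and not from a number, so the distance between chloro and trifluoromethyl remains unread: the limit of > 25 mg/kg in this assay, at which 1 of the 4 values shown sits.

From the compounds shown here alone, whether an amine, a carboxylic acid or a longer chain at this position would give a number beyond the scatter from those of the two halogen compounds stays open. Compound 1 gives "not determined" (no result reported) in this assay, so it offers no comparison, and the compounds shown do not say how the minimum effective dose responds to a different pattern of substitution on the aromatic ring.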